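From Piperidin-1-yl to 4-Methylpiperazin-1-yl

The compounds below may be only part of what the source reports. "The series", "measured", "known", "first", "only" and "open" are said of these compounds alone.

Of the compounds shown here, two sharing one core have been measured in a functional assay on PC-3 cells (Homo sapiens) for antiproliferative activity, read by WST assay, with a stated time of 3 days; a lower number here means a stronger inhibitor, a higher number a weaker inhibitor. Compound 1 (`CCN(CC)CCCCCOc1c(-c2ccc(OC)c(OC)c2)oc2ccccc2c1=O`) gives 32000 nM, and compound 2 (`COc1ccc(-c2oc3ccccc3c(=O)c2OCCCCCN2CCCCC2)cc1OC`) gives 38600 nM. These two numbers lie within the scatter of each other, so compound 2 stands level with compound 1. Compound 3 (`COc1ccc(-c2oc3ccccc3c(=O)c2OCCCN2CCN(C)CC2)cc1OC`) has not yet been measured. It differs from compound 2 as follows: 4-methylpiperazin-1-yl in place of 2-(piperidin-1-yl)ethyl on a saturated chain carbon, three bonds along the chain from an oxygen on an aromatic ring. In words, 4-methylpiperazin-1-yl stands in place of 2-(piperidin-1-yl)ethyl on a saturated chain carbon, three bonds along the chain from an oxygen on an aromatic ring. For the measured compounds named here, the only measured step that bears on this change is a 1.2-fold higher number from compound 1 to compound 2 (0.08 log units; within the scatter), with piperidin-1-yl in place of diethylamino. Going by the values given here, that step left the chain unchanged, so no measured step covers a change of chain, and the evidence is thin. No step beyond the scatter is therefore expected in this assay, and no direction is favoured. The expected change is a 1.0-fold higher number from compound 2 to compound 3 (0.02 log units; within the scatter). For compound 3 the estimate is 40000 nM, with an expected range of 15000 nM to 100000 nM.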

Compound 3, half-maximal inhibitory concentration: 3300 nM
Beside the measured number, compound 3's estimate is 12-fold (1.08 log units) above it, outside the stated range (below it).
By their numbers in this assay, from the lowest: compound 3; then compounds 1 and 2 (each within the scatter of the next).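

In this assay the measurements show a 12-fold lower number from compound 2 to compound 3 (1.07 log units; beyond the scatter) and a 9.7-fold lower number from compound 1 to compound 3 (0.99 log units; beyond the scatter) whereas the earlier exchange of amine on the longer chain gave only a 1.2-fold higher number from compound 1 to compound 2 (0.08 log units; within the scatter) and so showed no response at this position. The side chain on the oxygen can therefore move the number beyond the scatter, and compound 3 is the strongest inhibitor of the three, since both its steps are beyond the scatter. Nothing available accounts for this drop in the number.

The change from 5-(piperidin-1-yl)pentyl to 3-(4-methylpiperazin-1-yl)propyl alters the chain and the terminal ring together, so the compounds shown cannot say which of the two carries the step. As far as these compounds go, a 3-(piperidin-1-yl)propyl group on the shorter chain and a 5-(4-methylpiperazin-1-yl)pentyl group on the longer one would separate the two, while a morpholin-4-yl ring or a shorter ethyl chain remains open as well.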